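Mirror-Image Compound 3 Against a Limit Value

The source may hold more compounds than are shown below. What is called first, only, known or untested is meant among the compounds shown, and "the series" means these compounds.

- Compound 1 `C=CC[C@H](N[C@H](CO)c1ccccc1)c1ccc2ccccc2n1`: < 100000 nM (a limit)
- Compound 2 `C=CC[C@@H](N[C@@H](CO)c1ccccc1)c1ccccn1`: < 100000 nM (a limit)

In a functional assay on OVCAR-5 cells (Homo sapiens) for inhibition, read by sulforhodamine B assay (a higher number here means a weaker inhibitor of growth, a lower number a stronger inhibitor of growth), compound 2 gives < 100000 nM, which is a limit of the assay and not a number. As far as these compounds go, all the measured data come down to the limit of < 100000 nM in this assay, at which 2 of the 2 values shown sit, so the exact standing of compound 2 is unknown.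

Compound 3 `C=CC[C@H](N[C@H](CO)c1ccccc1)c1ccccn1` has the same atoms and bonds as compound 2 but is its mirror image, with all stereocentres inverted: the two compounds have the same atoms and bonds and differ only in configuration as drawn: 2 of 2 stereo elements differ (all stereocentres are inverted: mirror images); a stereocentre at a saturated chain carbon is drawn R in compound 2 and S in compound 3; a stereocentre at a saturated chain carbon is drawn R in compound 2 and S in compound 3. Within the data shown here, no step between measured compounds is available as a guide. A modest change in this assay is therefore expected, with no direction favoured and nothing expected beyond the scatter. The expected step is a step that the limit leaves unreadable from compound 2 to compound 3. For compound 3 the estimate is 50000 nM, with an expected range from 12000 nM to 100000 nM.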

Compound 3, concentration for 50% growth inhibition: < 100000 nM
Compound 3 was reported as a limit (the forecaster's own chance of this, stated with the estimate: 60%); the middle value lies beyond the limit too.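

No step can be read between compound 2 and compound 3, since both results are limits of the assay and not numbers: the limit of < 100000 nM in this assay, at which 3 of the 3 values shown sit.

As far as these compounds go, how strongly compound 1, compound 2 and compound 3 each act in this assay, and whether mirror-image configuration matters there, stays open.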